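The compounds below may be only part of what the source reports. "The series", "measured", "known", "first", "only" and "open" are said of these compounds alone.

Values in an assay on CHO cells for displacement of a labelled ligand from adenosine receptor A1 (Homo sapiens), with a stated time of 60 min, tested at 10 uM; on this read-out lower numbers stand for less inhibition and higher numbers for more inhibition at the one concentration tested (going by the name of the read-out):

Compound 1 `CCOC(=O)C1=C(C)N(C)C(=O)NC1c1cccs1` gives 2%.
Compound 2 `CC1=C(C(=O)OC(C)C)C(c2cccs2)NC(=O)N1C` gives 22%.
Compound 3 `CCOC(=O)C1=C(C)NC(=S)NC1c1ccoc1` gives 18%.

Compound 1 and compound 2 share a core and differ by methyl in place of hydrogen on a saturated chain carbon bound to an oxygen next to a carbonyl group and a saturated chain carbon. This change gave a number 20 percentage points higher from compound 1 to compound 2 (beyond the scatter). Compound 3 rests on a different core; the difference between the two cores is not broken down here. Compound 3 and compound 2 give numbers within the scatter of each other, while compound 3 lies above compound 1 by more than the scatter.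

Compound 4 `CC1=C(C(=O)OC(C)C)C(c2ccoc2)NC(=S)N1` is still to be measured and differs from compound 3 by methyl in place of hydrogen on a saturated chain carbon bound to an oxygen next to a carbonyl group and a saturated chain carbon. The place of the change reads the same word for word as for the earlier pair, so it is the same change on the other core. One prior example is a thin basis, and the cores differ, so the step is expected to be of like direction but taken with caution. Compound 4 is expected to give 35%, with a range from 15% to 55%. The expected step is a number 17 percentage points higher from compound 3 to compound 4 (beyond the scatter), resting on the earlier step, which gave a number 20 percentage points higher from compound 1 to compound 2 (beyond the scatter).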

Compound 4, a percentage reported as inhibition, at one concentration (the size of the read-out at that concentration, not a potency): 18%
Compound 4: the middle estimate sits 17 percentage points above what was measured, within the range that was stated.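

In this assay, isopropoxycarbonyl in place of ethoxycarbonyl gave no change at the digits printed from compound 3 to compound 4 (within the scatter), so the gain seen on the core of compound 1 did not carry over to the core of compound 3: the same change on two cores in this assay, a number 20 percentage points higher (beyond the scatter) from compound 1 to compound 2 and no change at the digits printed (within the scatter) from compound 3 to compound 4, 20 percentage points apart, beyond the scatter of two such steps

Within these two pairs, the outcome of this change depends on the core, and it cannot be assumed to transfer across the series. With a single pair on each core, this does not show which difference between the cores matters, nor how the change would behave on any further core.

The compounds shown leave open how a longer chain or a tert-butyl group on the ester oxygen would read on either core. They also leave open whether a carboxylic acid or an amide could stand in place of the ester.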